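A few compounds are considered here, and "the series" means these few. Any claim that something is new, unique, unknown or untested is made for them only; others in the source may bear on it.

Measured so far:
compound 1 `CCOC(=O)[C@@H]1CCCN(C(=O)c2ccc(S(=O)(=O)N(CC)CC)cc2)C1`: > 10000 nM, a limit
compound 2 `CCN(CC)C(=O)[C@@H]1CCCN(S(=O)(=O)c2ccc(S(=O)(=O)N(CC)CC)cc2)C1`: 6400 nM
compound 3 `CCOC(=O)[C@@H]1CCCN(S(=O)(=O)c2ccc(S(=O)(=O)N3CCCCC3)cc2)C1`: 2900 nM

In a functional assay on MIA PaCa-2 cells (Homo sapiens) for inhibition, read by MTT assay, with a stated time of 7 days (on this read-out lower numbers stand for stronger inhibition and higher numbers for weaker inhibition), compound 1 gives > 10000 nM, which is a limit of the assay and not a number (the limit of > 10000 nM in this assay, at which 1 of the 3 values shown sits). Among the two numbers, compound 2 at 6400 nM stands highest, and compound 3 at 2900 nM sits beyond the scatter below it.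

Compound 4 `CCN(CC)S(=O)(=O)c1ccc(S(=O)(=O)N2CCC[C@@H](C(=O)NC)C2)cc1` is not yet measured. Against compound 2 it carries methylamino in place of diethylamino on a carbonyl carbon. Among the measured compounds shown here, no measured step covers this change, so no direction is fixed; a step of no more than the scatter is expected in this assay, that is a 1.1-fold higher number from compound 2 to compound 4 (0.04 log units; within the scatter). Compound 4 is estimated at 7000 nM, within 2500 nM to 20000 nM, with a fair chance of returning only a limit.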

Compound 4, half-maximal inhibitory concentration: 8600 nM
Beside the measured number, compound 4's estimate is 1.2-fold (0.09 log units) below it; low and high end bracket the measured number.
By their numbers in this assay, from the lowest: compound 3; then compounds 2 and 4 (each within the scatter of the next). At a limit, above all of these: compound 1.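

In this assay, diethylamino and methylamino on this carbonyl carbon are not told apart: a 1.3-fold higher number from compound 2 to compound 4 (0.13 log units; within the scatter). Among the compounds shown here, this is the first single-place step read at this position, and it shows that the ethyl groups can go and an amide hydrogen can enter with the number staying within the scatter. Both amides sit in the upper part of the range, with the assay's limit close by: the limit of > 10000 nM in this assay, at which 1 of the 4 values shown sits.

Still open, going by these compounds, is whether an amide is needed on this saturated ring carbon at all, which a carboxylic acid or a hydroxymethyl group there would test. Also open, on these data alone, is how a cyclic amine such as morpholine on the carbonyl carbon would read.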